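Adding a second chlorine to compound 2

The source may hold more compounds than are shown below. What is called first, only, known or untested is meant among the compounds shown, and "the series" means these compounds.

Going by the values given here, compound 2 `CCCc1cc(N)c2cc(NC(=O)/C=C/c3ccc(Cl)cc3)ccc2n1` stands lowest of the two numbers measured so far in an assay on isolated protein for displacement of a labelled ligand from melanin-concentrating hormone receptor 1 (Homo sapiens) (a lower number here means a stronger inhibitor, a higher number a weaker inhibitor), where compound 2 gives 6 nM. Among the compounds with values here, its only measured neighbour is compound 1 `CCCc1cc(N)c2cc(NC(=O)/C=C/c3ccccc3Cl)ccc2n1`, which in this assay gives 120 nM; that move gave a 20-fold lower number from compound 1 to compound 2 (1.30 log units; beyond the scatter). Compound 3 `CCCc1cc(N)c2cc(NC(=O)/C=C/c3ccc(Cl)cc3Cl)ccc2n1` carries the change (chloro in place of hydrogen on an aromatic carbon), the entering chloro sitting ortho to a large group and meta to a chloro group, so that the 4-chlorophenyl of compound 2 becomes 2,4-dichlorophenyl. Within the data shown here, only the step from compound 1 to compound 2 bears on this, and only indirectly: it shows that a lone chloro in the place it held on compound 1 gave a much higher number than the lone chloro of compound 2, but it does not show what a further chloro does when the chloro of compound 2 is kept. The expectation for compound 3 in this assay is therefore a small step, if any, with a slight lean toward a higher number, a 1.7-fold higher number from compound 2 to compound 3 (0.22 log units; within the scatter). Compound 3 is thus estimated at 10 nM, within 3 nM to 40 nM.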

Compound 3, half-maximal inhibitory concentration: 6.6 nM
Compound 3: middle estimate off by 1.5-fold (0.18 log units), on the high side; the measured number falls inside the stated range.
By their numbers in this assay, from the lowest: compounds 2 and 3 (each within the scatter of the next); then compound 1.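

In this assay, a chloro ortho to a large group and meta to a chloro group leaves the number within the scatter (a 1.1-fold higher number from compound 2 to compound 3 (0.04 log units; within the scatter)), so on these two compounds this position takes a chloro without a readable change while the chloro of the 4-chlorophenyl stays in place. Read from the other side, the same kind of change gives a large step (an 18-fold lower number from compound 1 to compound 3 (1.26 log units; beyond the scatter)), which shows that the chloro of compound 1 does not by itself hold the number high: compound 3 keeps that chloro and still sits with compound 2, and compound 1, the only one of the three without the chloro of the 4-chlorophenyl, stands apart from both. No measurement shown here explains either step.

On these data alone, it remains open whether this position would take anything other than chloro in the same way, such as a methoxy group, a dimethylamino group or a carboxylic acid. The compounds shown also do not tell how a plain phenyl would compare, or whether a nitrile or a methoxy group could stand in for the chloro of the 4-chlorophenyl.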